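From a methoxyphenyl tail to an isopropylphenyl tail

The compounds below may be only part of what the source reports. "The series", "measured", "known", "first", "only" and "open" are said of these compounds alone.

Of the compounds shown here, three have so far been measured in an assay on isolated protein for inhibition of Polyunsaturated fatty acid 5-lipoxygenase (Homo sapiens), read by HPLC, with a stated time of 15 min, in the presence of a further agent that is not named here; on this read-out lower numbers stand for stronger inhibition and higher numbers for weaker inhibition. Compound 1 `CCCCC(Sc1ccc(OCCCOc2ccc(-c3ccccc3)cc2)cc1)C(=O)O` gives 900 nM. Compound 2 `Cc1cccc(OCCCOc2ccc(CCC(=O)O)cc2)c1C` reaches only the limit of the assay, > 10000 nM. Compound 3 `CCCCC(Sc1ccc(OCCCOc2ccccc2OC)cc1)C(=O)O` likewise reaches only the limit of the assay, > 10000 nM. Compound 3 therefore stands at the weak end of what is shown, sitting together with compound 2 at the limit of > 10000 nM in this assay, at which 2 of the 3 values shown sit, while compound 1 is the only one with a number. Going by the values given here, no two measured compounds differ in a single place, so no measured step is available.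

Compound 4 `CCCCC(Sc1ccc(OCCCOc2cccc(C(C)C)c2)cc1)C(=O)O` has not yet been measured. It differs from compound 3 by 3-isopropylphenyl in place of 2-methoxyphenyl on an oxygen on a saturated carbon. Compound 1, which carries a different aryl group on that oxygen, gives 900 nM, showing that this part of the molecule can be varied without losing all inhibition. The step of an at least 3.3-fold lower number from compound 3 to compound 4 (0.52 log units; beyond the scatter) is expected to go toward stronger inhibition, beyond the usual scatter, though its size is uncertain from a limit. In this assay compound 4 is estimated at 3000 nM, within 700 nM to 12000 nM.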

Compound 4, half-maximal inhibitory concentration: 1400 nM
Compound 4: middle estimate off by 2.1-fold (0.33 log units), on the high side; the measured number falls inside the stated range.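

In this assay, 3-isopropylphenyl in place of 2-methoxyphenyl on an oxygen on a saturated carbon brings an at least 7.1-fold lower number from compound 3 to compound 4 (0.85 log units; beyond the scatter), so a single change at this position on the shared core is enough to yield a measurable number. Compound 3 carries only a limit, > 10000 nM. The step therefore gives only a minimum size, and how far it extends remains unknown: the limit of > 10000 nM in this assay, at which 2 of the 4 values shown sit.

This change replaces the substituent and alters where it sits on the ring in one move, so the compounds shown cannot separate the two contributions. Going by these compounds, a 3-methoxyphenyl or 2-isopropylphenyl group at this position would tell them apart, and how an amine on this ring would read in this assay remains open.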